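Methyl on the pendant phenyl: carrying one step across two cores

The source may hold more compounds than are shown below. What is called first, only, known or untested is meant among the compounds shown, and "the series" means these compounds.

Measured so far:
compound 1, `Cn1c(=O)n(C)c2c(Oc3ccc(NC(=O)Nc4cc(C(C)(C)C)nn4-c4ccccc4)c(F)c3)ccnc21`: 2.1 h
compound 2, `Cc1ccc(-n2nc(C(C)(C)C)cc2NC(=O)Nc2ccc(Oc3ccnc4c3n(C)c(=O)n4C)cc2F)cc1`: 9.4 h
compound 3, `CC(C)(C)c1cc(NC(=O)Nc2ccc(Oc3ccnc4[nH]c(=O)[nH]c34)cc2F)n(-c2ccccc2)n1`: 2.8 h

In an in vivo ADME assay on the whole organism (strain BALB/cAnNCrl) for metabolic stability, with Mus musculus as the target, at a dose of 10 mg/kg by the oral route (on this read-out lower numbers stand for a shorter-lived compound and higher numbers for a longer-lived compound), compound 1 gives 2.1 h. Compound 2 differs from compound 1 by methyl in place of hydrogen on an aromatic carbon and in this assay compound 2 gives 9.4 h, so that a 4.5-fold higher number from compound 1 to compound 2 (0.65 log units; beyond the scatter). Compound 3 differs from compound 1 in the core, namely (a group of 10 heavy atoms (6 carbon, 3 nitrogen, 1 oxygen; one five-membered aromatic ring with 2 hetero atoms, one six-membered aromatic ring with 1 hetero atom) in place of a group of 12 heavy atoms (8 carbon, 3 nitrogen, 1 oxygen; one five-membered aromatic ring with 2 hetero atoms, one six-membered aromatic ring with 1 hetero atom), on an oxygen on an aromatic ring); in this assay compound 3 gives 2.8 h, and a 1.3-fold higher number from compound 1 to compound 3 (0.12 log units; within the scatter), so the two cores cannot be told apart on this read-out.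

Compound 4, `Cc1ccc(-n2nc(C(C)(C)C)cc2NC(=O)Nc2ccc(Oc3ccnc4[nH]c(=O)[nH]c34)cc2F)cc1`, is not yet measured. It differs from compound 3 by methyl in place of hydrogen on an aromatic carbon, the same change that carries compound 1 to compound 2, made on the core of compound 3 instead. Among the compounds with values here, because a 4.5-fold higher number from compound 1 to compound 2 (0.65 log units; beyond the scatter), a step of similar size is expected here, tempered a little for the single precedent: compound 4 is expected to sit at a 3.4-fold higher number from compound 3 to compound 4 (0.53 log units; beyond the scatter) above compound 3. The estimate for compound 4 in this assay is therefore 9.5 h, with a likely range of 4 h to 22 h.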

Compound 4, half-life: 5.3 h
For compound 4 the middle estimate is 1.8-fold (0.25 log units) above the measured one, and the stated range covers the measured number.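

In this assay, the change from phenyl to 4-methylphenyl on the core of compound 3 gives a 1.9-fold higher number from compound 3 to compound 4 (0.28 log units; within the scatter), and this step cannot be told apart from the one on the core of compound 1: the same change on two cores in this assay, a 4.5-fold higher number (0.65 log units; beyond the scatter) from compound 1 to compound 2 and a 1.9-fold higher number (0.28 log units; within the scatter) from compound 3 to compound 4, 2.4-fold (0.37 log units) apart, within the scatter of two such steps

With the methyl in place, the change of core gives a 1.8-fold lower number from compound 2 to compound 4 (0.25 log units; within the scatter), which also cannot be told apart from the same change of core without the methyl: the same change on two cores in this assay, a 1.3-fold higher number (0.12 log units; within the scatter) from compound 1 to compound 3 and a 1.8-fold lower number (0.25 log units; within the scatter) from compound 2 to compound 4, 2.4-fold (0.37 log units) apart, within the scatter of two such steps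

The two pairs are therefore compatible with the methyl step carrying over between these cores, but they do not establish it: the step is beyond the scatter on the core of compound 1 and within it on the core of compound 3, and two pairs can neither fix a common size nor show that the size depends on the core.

From the compounds shown here alone, it remains open whether an ethyl, a methoxy or a chlorine in place of the methyl would give a step of similar size. Also open, going by these compounds, is whether the methyl step would carry over to a third core.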